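From compound 2 to compound 4: a sulfanyl group returns

The compounds below may be only part of what the source reports. "The series", "measured", "known", "first", "only" and "open" are said of these compounds alone.

In a functional assay on MV4-11 cells (Homo sapiens) for inhibition, read by resazurin assay, with a stated time of 72 h (on this read-out higher numbers stand for weaker inhibition of growth and lower numbers for stronger inhibition of growth), compound 2 `COCCOc1nc(C)c(-c2ccnc(Nc3ccc(OC)cc3OC)n2)s1` gives 1980 nM. Compound 3 `CCCn1cc(-c2ccnc(Nc3ccc(OC)cc3OC)n2)c2ccccc21` gives 3620 nM, within the scatter of compound 2. Compound 1 `COc1ccc(Nc2nccc(-c3sc(SC(C)C)nc3C)n2)c(OC)c1` gives 5670 nM, and the gap to compound 2 lies beyond the scatter.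

The change to compound 4 `COc1ccc(Nc2nccc(-c3sc(SCc4cccnc4)nc3C)n2)c(OC)c1` is ((pyridin-3-yl)methyl)sulfanyl in place of 2-methoxyethoxy on an aromatic carbon. Within the data shown here, one measured step bears on it: a 2.9-fold lower number from compound 1 to compound 2 (0.46 log units; beyond the scatter), which replaced isopropylsulfanyl with 2-methoxyethoxy. Among the measured compounds shown here, compound 4 restores a sulfanyl group, but one bearing a pyridine ring, and no measured compound carries that ring. A modest rise in this assay is therefore expected, close in size to that single step. The expected change is a 2.1-fold higher number from compound 2 to compound 4 (0.33 log units; beyond the scatter). The estimate for compound 4 is 4200 nM, with an expected range of 1400 nM to 12000 nM.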

Compound 4, concentration for 50% growth inhibition: 270 nM
The estimate for compound 4 lay 16-fold (1.19 log units) above the measured number; the whole stated range lies above it.
By their numbers in this assay, from the lowest: compound 4; then compounds 2, 3 and 1 (each within the scatter of the next, the first and the last beyond it).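

In this assay the sulfur is kept and only its substituent changes, yet (pyridin-3-yl)methyl in place of isopropyl gives a 21-fold lower number from compound 1 to compound 4 (1.32 log units; beyond the scatter) and so shows that the group carried on sulfur strongly affects the number at this position. Replacing 2-methoxyethoxy with ((pyridin-3-yl)methyl)sulfanyl gives a 7.3-fold lower number from compound 2 to compound 4 (0.87 log units; beyond the scatter) and so reverses the order seen between 2-methoxyethoxy and isopropylsulfanyl. Nothing available accounts for this gain.

Open, from the compounds shown here alone, is whether a benzyl group on the same sulfur would match (pyridin-3-yl)methyl, which would test the need for the ring nitrogen. Also open, going by these compounds, is whether a pyridin-2-ylmethyl or pyridin-4-ylmethyl group would do the same.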